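The source may report more compounds than this note shows. Statements on the series, on what has been measured and on what is new or still open speak of the compounds shown alone.

Among the compounds with values here, in a physicochemical assay for solubility (a higher number here means a more soluble compound, a lower number a less soluble compound), three compounds have a measured number so far. Compound 1 `O=C1CCCN1c1ccc(S(=O)(=O)N2CCOc3ccccc32)cc1` gives 26600 nM, compound 3 `COc1ccc2c(c1)N(C)CCN2S(=O)(=O)c1ccc(N2CCCC2=O)cc1` gives 69600 nM, and compound 2 `O=C1CCCN1c1ccc(S(=O)(=O)N2CCCc3cc(Cl)ccc32)cc1` gives 2900 nM, the lowest of the three; the gaps between compound 2 and each of the other two lie beyond the usual scatter of repeated measurements. Compound 4 `O=C1CCCN1c1ccc(S(=O)(=O)N2CCCc3ccccc32)cc1` has not yet been measured. It differs from compound 2 in one place: hydrogen in place of chloro on an aromatic carbon. Within the data shown here, no measured pair shows this change on its own, so the size of the step is uncertain. Compound 2 sits at the bottom of the measured range. An upward step is expected, estimated at a 3.1-fold higher number from compound 2 to compound 4 (0.49 log units; beyond the scatter). For compound 4 the expected value in this assay is 9000 nM, with a range from 3500 nM to 24000 nM.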

Compound 4, solubility: 7800 nM
Beside the measured number, compound 4's estimate is 1.2-fold (0.06 log units) above it, and the stated range covers the measured number.
By their numbers in this assay, from the lowest: compound 2; then compound 4; then compound 1; then compound 3.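

In this assay, hydrogen in place of chloro on this aromatic carbon gives a 2.7-fold higher number from compound 2 to compound 4 (0.43 log units; beyond the scatter). Within the data shown here, this is the first pair in the set that differs in one place only, so the gap can be read for this single change, and it shows that the group on this carbon alone can move the number. No supporting measurement accounts for the size or direction of this step.

The compounds shown leave open how fluoro, an amine or a carboxylic acid on this carbon would read. Going by these compounds, whether the same change gives a similar step on the core of compound 1 also remains open.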